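This account rests on a few compounds, and the source may have more. Where it says the series, first, only, none or still open, it means among the compounds named here.

Working notes on the series. Compound 1 `Clc1ccc(C2CC(c3ccc(N4CCCCC4)cc3)=NN2c2nc(-c3ccccc3)cs2)cc1` gives 28400 nM in a functional assay on MCF7 cells (Homo sapiens) for antiproliferative activity, read by MTT assay, with a stated time of 72 h (on this read-out higher numbers stand for weaker inhibition and lower numbers for stronger inhibition), and holds the only number shown in this assay. Compound 2 `Cc1ccc(-c2csc(N3N=C(c4ccc(N5CCCCC5)cc4)CC3c3ccc(Cl)cc3)n2)cc1` reports in this assay only a limit, > 100000 nM. The step of an at least 3.5-fold higher number from compound 1 to compound 2 (0.54 log units; beyond the scatter), methyl in place of hydrogen on an aromatic carbon, rests on (the limit of > 100000 nM in this assay, at which 1 of the 2 values shown sits).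

Compound 3 `Clc1ccc(C2CC(c3ccc(N4CCCCC4)cc3)=NN2c2nc(-c3ccc4ccccc4c3)cs2)cc1` differs from compound 1 by naphthalen-2-yl in place of phenyl on an aromatic carbon. Among the measured compounds shown here, the only measured step that bears on this is an at least 3.5-fold higher number from compound 1 to compound 2 (0.54 log units; beyond the scatter), which also changes the group on the aromatic carbon of the five-membered aromatic ring with one nitrogen and one sulfur, and it raised the number. A rise beyond the scatter is therefore expected here as well, with a fair chance that this assay returns only a limit. The expected step is a 2.3-fold higher number from compound 1 to compound 3 (0.36 log units; beyond the scatter). Compound 3 is estimated at 65000 nM, within a range from 25000 nM to 160000 nM.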

Compound 3, half-maximal inhibitory concentration: > 100000 nM
Compound 3: only a limit was reported; the forecaster's own chance of this, stated with the estimate: 40%; middle value at least 1.5-fold (0.18 log units) away from the limit.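

Naphthalen-2-yl in place of phenyl on this aromatic carbon gives an at least 3.5-fold higher number from compound 1 to compound 3 (0.54 log units; beyond the scatter) in this assay, so a second replacement at this position moves the number the same way as the first. Of the three groups shown here, only phenyl in compound 1 keeps a measured number, and 4-methylphenyl in compound 2 and naphthalen-2-yl in compound 3 go the same way, with no compound against this among those shown. Compound 3 gives only a limit, so the step from compound 2 to compound 3 cannot be read, and the two replacements cannot be ranked: the limit of > 100000 nM in this assay, at which 2 of the 3 values shown sit.

On these data alone, it remains open whether any group at this position gives a lower number than compound 1 does at 28400 nM in this assay. A small amine, a carboxylic acid or a 4-fluorophenyl group would test this.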